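Quinazoline cytotoxicity: swapping the aryl amine head group

This account rests on a few compounds, and the source may have more. Where it says the series, first, only, none or still open, it means among the compounds named here.

Measured compounds:
- compound 1 `CCS(=O)(=O)Nc1cc(-c2ccc3ncnc(Nc4ccc(OC(F)(F)F)cc4)c3c2)cnc1OC`: 6140 nM
- compound 2 `CCS(=O)(=O)Nc1cc(-c2ccc3ncnc(Nc4ccc(OCc5ccc(F)cc5)c(Cl)c4)c3c2)cnc1OC`: 1950 nM

The two compounds share a core and differ only in the aryl group on the amine. In a functional assay on SK-HEP1 cells (Homo sapiens) for cytotoxicity, read by sulforhodamine B assay, with a stated time of 72 h (on this read-out higher numbers stand for weaker inhibition and lower numbers for stronger inhibition), compound 1 gives 6140 nM, the higher of the two numbers, while compound 2 gives 1950 nM, a gap that lies beyond the scatter. For the measured compounds named here, no single-point step between these two is counted, so their values are simply read side by side.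

The compound not yet measured is compound 3 `CCS(=O)(=O)Nc1cc(-c2ccc3ncnc(Nc4ccc(F)nc4)c3c2)cnc1OC`. Relative to compound 1 the change is 6-fluoropyridin-3-yl in place of 4-(trifluoromethoxy)phenyl on a nitrogen on an aromatic ring. The entering group is smaller than the leaving one and carries a ring nitrogen in place of the trifluoromethoxy substituent.

Only compound 1 anchors this change, and it already stands at the weaker end of what is shown. The step from compound 1 to compound 3 is expected to be a 1.6-fold higher number from compound 1 to compound 3 (0.21 log units; within the scatter), a modest move towards weaker inhibition, because compound 1 starts from 6140 nM and the replacement removes the larger aryl group that the more potent compound 2 also carries in extended form. Compound 3 is therefore estimated at 10000 nM, with a range of 3000 nM to 30000 nM.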

Compound 3, half-maximal inhibitory concentration: 5240 nM
The estimate for compound 3 lay 1.9-fold (0.28 log units) above the measured number; low and high end bracket the measured number.
By their numbers in this assay, from the lowest: compound 2; then compounds 3 and 1 (each within the scatter of the next).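

In this assay, the step of a 1.2-fold lower number from compound 1 to compound 3 (0.07 log units; within the scatter) shows that 6-fluoropyridin-3-yl in place of 4-(trifluoromethoxy)phenyl on a nitrogen on an aromatic ring leaves the read-out within the scatter. The earlier compounds shown here offered no single-place step anchored on this change, and this one shows that an entering group of 7 heavy atoms with a ring nitrogen reads the same in this assay as a leaving group of 11 heavy atoms with a carbon-only ring. Nothing measured here accounts for this outcome, and the ring nitrogen and the loss of the trifluoromethoxy group cannot be separated, as both change in the same step.

As far as these compounds go, what remains open is whether any simple replacement at this position moves the number, for instance a pyridine ring carrying an amine or a methoxy group in place of the fluorine, or a plain phenyl ring. Also open, from the compounds shown here alone, is which part of the larger aryl group of compound 2, at 1950 nM, goes with its lower number, since a benzyloxy group without the chlorine, or a chlorine alone, would be needed to tell them apart.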